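Pyrrolidinyl for dimethylamino on the indole ethyl chain

A few compounds are considered here, and "the series" means these few. Any claim that something is new, unique, unknown or untested is made for them only; others in the source may bear on it.

Measured compounds:
Compound 1 `CN(C)CCn1ccc2cc(NS(=O)(=O)Cc3ccccc3)ccc21` gives > 1000 nM in an assay on HEK293 cells for binding affinity to 5-hydroxytryptamine receptor 6 (Homo sapiens); a lower number here means a stronger inhibitor, a higher number a weaker inhibitor.
Compound 2 `CN(C)CCn1ccc2ccc(NS(=O)(=O)CCc3cccc4ccccc34)cc21` gives 74.5 nM.
Compound 3 `O=S(=O)(Nc1ccc2ccn(CCN3CCCC3)c2c1)c1cccc2ccccc12` gives 18.6 nM.

For compound 1 the value is a limit of this assay, not a number (the limit of > 1000 nM in this assay, at which 1 of the 3 values shown sits). Among the two numbers, compound 2 has the higher one, and compound 3 sits a step lower than compound 2 that lies beyond the scatter. Compound 4 `O=S(=O)(CCc1cccc2ccccc12)Nc1ccc2ccn(CCN3CCCC3)c2c1` differs from compound 2 in one place: pyrrolidin-1-yl in place of dimethylamino on a saturated chain carbon, two bonds along the chain from an aromatic nitrogen. Among the measured compounds shown here, no measured pair shows this change on its own. The step from compound 2 to compound 4 is expected to be small, toward a somewhat lower number or none beyond the scatter, as a 1.7-fold lower number from compound 2 to compound 4 (0.22 log units; within the scatter). Compound 4 is therefore estimated at 45 nM, with a range from 15 nM to 150 nM.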

Compound 4, inhibition constant: 195 nM
Compound 4: middle estimate off by 4.3-fold (0.64 log units), on the low side, outside the stated range (above it).
By their numbers in this assay, from the lowest: compound 3; then compound 2; then compound 4. At a limit, above all of these: compound 1.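

Among the compounds shown here, this is the first direct reading of the change. With the rest of the molecule held constant in this assay, replacing dimethylamino with pyrrolidin-1-yl gives a 2.6-fold higher number from compound 2 to compound 4 (0.42 log units; beyond the scatter), so the new group does not by itself bring a lower number here. Compound 3 gives 18.6 nM, but compound 4 carries the same pyrrolidin-1-yl group and gives 195 nM, and nothing measured here gives a cause for the step.

From the compounds shown here alone, whether the step holds with the sulfonyl group of compound 3 remains open. So does how piperidin-1-yl or morpholin-4-yl on the same chain would compare.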